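The source may report more compounds than this note shows. Statements on the series, on what has been measured and on what is new or still open speak of the compounds shown alone.

Values in an ADME assay on Huh-7 cells (Homo sapiens) for cytotoxicity, with a stated time of 72 h; a higher number here means that more compound is tolerated, a lower number that less compound is tolerated:

- compound 1 `CS(=O)(=O)Nc1ccc2c(c1)S(=O)(=O)N=C(c1c(O)c(-c3cccs3)nn(CC3CCC3)c1=O)N2` gives > 1000 nM
- compound 2 `COCCn1nc(-c2cccs2)c(O)c(C2=NS(=O)(=O)c3cc(NS(C)(=O)=O)ccc3N2)c1=O` gives > 1000 nM
- compound 3 `CS(=O)(=O)Nc1ccc2c(c1)S(=O)(=O)N=C(c1c(O)c(-c3cccs3)nn(CCC3CCC3)c1=O)N2` gives > 1000 nM

Each of these values is a limit of the assay and not a number. Compound 3 therefore has no readable rank in the series and sits with the others at the limit of > 1000 nM in this assay, at which 3 of the 3 values shown sit.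

Compound 4 `CS(=O)(=O)Nc1ccc2c(c1)S(=O)(=O)N=C(c1c(O)c(-c3cccs3)nn(Cc3ccc(F)cc3)c1=O)N2` carries 4-fluorophenyl in place of cyclobutylmethyl on a saturated chain carbon bound to an aromatic nitrogen, with the counted difference being (4-fluorophenyl in place of cyclobutylmethyl on a saturated chain carbon bound to an aromatic nitrogen).

Three measured changes bear on this place: a step that the two limits leave unreadable from compound 1 to compound 3, a step that the two limits leave unreadable from compound 1 to compound 2 and a step that the two limits leave unreadable from compound 2 to compound 3. For the measured compounds named here, none of them gives a size, so they set no scale, and no measured compound carries 4-fluorophenyl here.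

With only the limit of compound 3 at > 1000 nM as a reference, no step beyond the scatter is expected in either direction. The estimated step is a step that the limit leaves unreadable from compound 3 to compound 4 as the expected outcome. The value expected for compound 4 is 1200 nM, with an estimated range from 700 nM to 5000 nM, and a further limit is the likeliest report.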

Compound 4, half-maximal cytotoxic concentration: > 1000 nM
Compound 4: no number, only a limit (the forecaster's own chance of this, stated with the estimate: 85%); the middle value does not contradict the limit.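

In this assay compound 4 gives > 1000 nM, again a limit and not a number, so its steps from compound 1, compound 2 and compound 3 cannot be read: the limit of > 1000 nM in this assay, at which 4 of the 4 values shown sit.

Still open, going by these compounds, is whether the group on a saturated chain carbon bound to an aromatic nitrogen changes the half-maximal cytotoxic concentration at all.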